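The compounds below may be only part of what the source reports. "The series", "measured", "known", "first", "only" and "open" are said of these compounds alone.

Working notes on the series. Compound 1 `Cc1ccc(S(=O)(=O)Oc2ccc3c(c2C)[C@H](Cn2cc(-c4ccc(Br)cc4)nn2)[C@@]24CC(=O)[C@@](C)(CC[C@@H]32)C4)cc1` carries a 4-bromophenyl on the triazole. In a functional assay on SW480 cells (Homo sapiens) for cytotoxicity, read by MTT assay, with a stated time of 4 days (on this read-out lower numbers stand for stronger inhibition and higher numbers for weaker inhibition), compound 1 gives > 20000 nM, which is a limit of the assay and not a number. Compound 2 `C=C1C[C@]23C[C@@]1(O)CC[C@H]2c1ccc(O)c(C)c1[C@@H]3Cn1cc(-c2ccc(C)cc2)nn1` belongs to the same set and is also only known by a limit: in this assay compound 2 gives > 20000 nM. Within the data shown here, both values shown so far therefore sit at the limit of > 20000 nM in this assay, at which 2 of the 2 values shown sit, and no step between two measured compounds that differ in one place is available.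

Compound 3 `Cc1ccc(-c2cn(C[C@H]3c4c(ccc(OS(=O)(=O)c5ccc(C)cc5)c4C)[C@@H]4CC[C@@]5(C)C[C@]43CC5=O)nn2)cc1` differs from compound 1 as follows: methyl in place of bromo on an aromatic carbon. With both measured compounds at the limit, there is no basis for expecting a step in either direction beyond the scatter. Compound 3 is therefore expected to sit near the same limit, with the estimated step that the limit leaves unreadable from compound 1 to compound 3 being essentially none. The estimate for compound 3 in this assay is 25000 nM, in a range from 10000 nM to 60000 nM.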

Compound 3, half-maximal inhibitory concentration: > 20000 nM
Compound 3 was reported as a limit (the forecaster's own chance of this, stated with the estimate: 80%); the middle value is on the limit's open side.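

Compound 1 and compound 3 both sit at a limit of the assay and not at a number, so no step between them can be read: the limit of > 20000 nM in this assay, at which 3 of the 3 values shown sit.

The compounds shown leave open whether any member of this set reaches a readable value in this assay, and how bromo and methyl compare there.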